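Lengthening an Ether Chain: What to Expect for Compound 4

The compounds below may be only part of what the source reports. "The series", "measured", "known", "first", "only" and "open" are said of these compounds alone.

Three compounds have been measured in a functional assay on HT-29 cells (Homo sapiens) for cytotoxicity, read by MTT assay; on this read-out lower numbers stand for stronger inhibition and higher numbers for weaker inhibition:
compound 1, `CCCOc1ccc(O)c(C(=O)/C=C/c2ccc(C)s2)c1`, 126000 nM
compound 2, `Cc1ccc(/C=C/C(=O)c2cc(OCC(C)C)ccc2O)s1`, 30700 nM
compound 3, `CCCOc1ccc(OC)cc1C(=O)/C=C/c1ccc(C)s1`, 86600 nM

Compound 2 differs from compound 1 by methyl in place of hydrogen on a saturated chain carbon bound to two saturated chain carbons. That change gave a 4.1-fold lower number from compound 1 to compound 2 (0.61 log units; beyond the scatter). Compound 3 differs from compound 1 in more than one place, and the difference between the two cores is not broken down here. In this assay compound 3 and compound 1 lie within the scatter of each other, while compound 2 shows a lower number than compound 3.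

Compound 4, `CCCCOc1ccc(OC)cc1C(=O)/C=C/c1ccc(C)s1`, has not yet been measured. It differs from compound 3 by methyl in place of hydrogen on a saturated chain carbon, three bonds along the chain from an oxygen on an aromatic ring. Going by the values given here, this is the same kind of change as the one made between compound 1 and compound 2, but not the same: in the earlier pair the methyl entered on a saturated chain carbon bound to two saturated chain carbons, whereas here it enters on a saturated chain carbon three bonds along the chain from an oxygen on an aromatic ring. Among the compounds with values here, the earlier change gave a 4.1-fold lower number from compound 1 to compound 2 (0.61 log units; beyond the scatter), so a lower number is expected for compound 4 as well, though a smaller step: the place differs, and only a single example supports it. The expected step is a 1.9-fold lower number from compound 3 to compound 4 (0.28 log units; within the scatter). Compound 4 is therefore estimated at 45000 nM in this assay, with a range from 15000 nM to 130000 nM.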

Compound 4, half-maximal inhibitory concentration: 61100 nM
Estimate against measurement, compound 4: 1.4-fold (0.13 log units) below, and the stated range covers the measured number.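

In this assay, the added methyl gave a 1.4-fold lower number from compound 3 to compound 4 (0.15 log units; within the scatter), so on this core the change from a propyl to a butyl ether cannot be told apart from the ordinary spread of repeated measurements. Set beside the earlier step, the size of the effect did not carry over from one core to the other: the same change on two cores in this assay, a 4.1-fold lower number (0.61 log units; beyond the scatter) from compound 1 to compound 2 and a 1.4-fold lower number (0.15 log units; within the scatter) from compound 3 to compound 4, 2.9-fold (0.46 log units) apart, beyond the scatter of two such steps

This does not show what sets the two steps apart, since the two pairs differ both in the core and in the place where the methyl enters, and two pairs are too few to support a rule for the series in either direction.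

The compounds shown leave open what the branched chain of compound 2 would do on the core of compound 3, a comparison that would keep the place of the methyl the same and change only the core. Also open, going by these compounds, is how a chain longer than butyl, or an ether chain carrying an amine or a carboxylic acid, would read in this assay.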